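The compounds below may be only part of what the source reports. "The series", "measured", "known", "first", "only" and "open" are said of these compounds alone.

Measured compounds:
Compound 1, `CCCCCCCCCC(=O)O[C@H]1[C@H](O)[C@H](n2ccc(N)nc2=O)O[C@@H]1CO`: 0.09 ug/mL
Compound 2, `CCCCCCCCCC(=O)OC[C@H]1O[C@@H](n2ccc(N)nc2=O)[C@@H](O)[C@@H]1OC(=O)CCCCCCCCC`: 0.11 ug/mL
Compound 3, `CCCCCCCCCCCCCCCCCC(=O)OC[C@H]1O[C@@H](n2ccc(N)nc2=O)[C@@H](O)[C@@H]1OC(=O)CCCCCCCCCCCCCCCCC`: 10 ug/mL

In a functional assay on HeLa cells (Homo sapiens) for cytotoxicity, read by cell counting, with a stated time of 48 h (on this read-out lower numbers stand for an effect already at smaller amounts and higher numbers for an effect only at larger amounts of compound), compound 1 gives the lowest number of the three. Compound 2 sits close to it, with a 1.2-fold higher number from compound 1 to compound 2 (0.09 log units; within the scatter), a step that does not exceed the scatter, so the two cannot be placed in any order. Among the compounds with values here, compound 3, which carries much longer ester chains on the same core, gives 10 ug/mL, a far higher number than compound 2 gives with 0.11 ug/mL; the two values show that the length of the ester chains matters greatly in this assay, although only one such comparison is available.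

Compound 4, `CCCC(=O)O[C@H]1[C@H](O)[C@H](n2ccc(N)nc2=O)O[C@@H]1CO`, has not yet been measured. Compared with compound 1 the change is hydrogen in place of hexyl on a saturated chain carbon, three bonds along the chain from a carbonyl carbon; the ester is kept, only its chain is shortened. Within the data shown here, no measured step shortens a chain. The step from compound 1 to compound 2 shows that a further nonylcarbonyl leaves the number almost unchanged, while compounds 2 and 3 show that far longer chains raise it strongly. The expectation for compound 4 is therefore a modest shift, a 3.3-fold higher number from compound 1 to compound 4 (0.52 log units; beyond the scatter), giving an estimate of 0.3 ug/mL with a range from 0.08 ug/mL to 1.5 ug/mL.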

Compound 4, concentration for half-maximal effect: 0.11 ug/mL
The estimate for compound 4 lay 2.7-fold (0.44 log units) above the measured number; the range from low to high includes it.
By their numbers in this assay, from the lowest: compounds 1, 2 and 4 (each within the scatter of the next); then compound 3.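

In this assay, hydrogen in place of hexyl on a saturated chain carbon, three bonds along the chain from a carbonyl carbon gives a 1.2-fold higher number from compound 1 to compound 4 (0.09 log units; within the scatter), so these two compounds cannot be told apart. This is the only step shown that shortens the ester chain at this place, and it shows that the hexyl part of the chain can be removed without a measurable difference on this read-out, as long as the ester itself stays. The data shown offer no measurement that would explain this result.

The compounds shown leave open how the number responds to an ester chain longer than that of compound 1 on this same oxygen, and to an amine or a carboxylic acid in place of the hexyl. Also open, on these data alone, is what a plain hydroxyl in place of the whole ester would give, and so whether any ester chain at this place is needed for the effect.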